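The source may report more compounds than this note shows. Statements on the series, on what has been measured and on what is new or still open speak of the compounds shown alone.

In a functional assay on HL-60 cells (Homo sapiens) for cytotoxicity, read by luminescence and CellTiter-Glo, with a stated time of 3 days (a lower number here means a stronger inhibitor, a higher number a weaker inhibitor), compound 2 `COc1cccc(C(=O)Nc2ccc(C#N)cc2)c1O` gives > 10000 nM, which is a limit of the assay and not a number. On these data alone, it therefore sits at the limit of > 10000 nM in this assay, at which 1 of the 2 values shown sits, and its true position is unknown. For the measured compounds named here, the one measured neighbour carries bromo in place of the methoxy: compound 1 `N#Cc1ccc(NC(=O)c2cccc(Br)c2O)cc1` gives 2910 nM. The measured step is an at least 3.4-fold higher number from compound 1 to compound 2 (0.53 log units; beyond the scatter), so swapping this single group has already moved the number beyond the scatter.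

Compound 3 `Cc1cccc(C(=O)Nc2ccc(C#N)cc2)c1O` differs from compound 2 by one change, methyl in place of methoxy on an aromatic carbon, ortho to a hydroxy group: methyl in place of methoxy on an aromatic carbon. Going by the values given here, no methyl compound has been measured yet, so the only guide is the step of an at least 3.4-fold higher number from compound 1 to compound 2 (0.53 log units; beyond the scatter), in which the compound with methoxy had the higher number. On that basis, a modest move towards a lower number is expected in this assay, although the reading could again stop at the limit. The expected change is an at least 1.8-fold lower number from compound 2 to compound 3 (0.25 log units; that floor lies within the scatter). For compound 3 the estimated value is 5500 nM, with an expected range of 2000 nM to 10000 nM.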

Compound 3, half-maximal inhibitory concentration: > 10000 nM
Compound 3: only a limit was reported (the forecaster's own chance of this, stated with the estimate: 35%); middle value at least 1.8-fold (0.25 log units) from the limit.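

In this assay, methyl in place of bromo gives an at least 3.4-fold higher number from compound 1 to compound 3 (0.53 log units; beyond the scatter), so the drop seen with methoxy is not peculiar to methoxy: a second, smaller group that carries no oxygen also fails to keep the reading of compound 1. Of the three groups shown at this position, ortho to a hydroxy group, only bromo gives a reading inside the range of the assay, and compound 3 gives > 10000 nM, which is a limit of the assay and not a number. The step between compound 2 and compound 3 cannot be read, and methyl and methoxy cannot be ranked against each other, because both values are limits: the limit of > 10000 nM in this assay, at which 2 of the 3 values shown sit.

The compounds shown leave open whether the activity belongs to bromo alone or would also appear with another halogen such as chloro or iodo, or with a group such as trifluoromethyl or an amine. They also leave open how far the true values of compound 2 and compound 3 lie beyond the limit. On these data alone, whether any other group here could match or improve on compound 1, at 2910 nM, is likewise open.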